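Carbonyl side-group swap from compound 3 to compound 4

A few compounds are considered here, and "the series" means these few. Any claim that something is new, unique, unknown or untested is made for them only; others in the source may bear on it.

In a functional assay on A549 cells (Homo sapiens) for inhibition, read by MTT assay, with a stated time of 72 h (on this read-out higher numbers stand for weaker inhibition and lower numbers for stronger inhibition), compound 1 `C=C(Cl)C(=O)Nc1cc(Nc2nc3c(c(-c4cn(C)c5ccccc45)n2)CSCC3)c(OC)cc1N(C)CCN(C)C` gives 716 nM, compound 2 `CC/C=C\C(=O)Nc1cc(Nc2nc3c(c(-c4cn(C)c5ccccc45)n2)CSCC3)c(OC)cc1N(C)CCN(C)C` gives 236 nM and compound 3 `C=C(Cl)C(=O)Nc1cc(Nc2nc3c(c(-c4cn(C)c5ccccc45)n2)CS(=O)(=O)CC3)c(OC)cc1N(C)CCN(C)C` gives 881 nM. Compound 3 thus sits within the scatter of compound 1 and beyond the scatter of compound 2. Compound 4 `CC/C=C\C(=O)Nc1cc(Nc2nc3c(c(-c4cn(C)c5ccccc45)n2)CS(=O)(=O)CC3)c(OC)cc1N(C)CCN(C)C` is compound 3 with one change: but-1-en-1-yl in place of 1-chloroethenyl on a carbonyl carbon. The same exchange has one measured precedent, a 3.0-fold lower number from compound 1 to compound 2 (0.48 log units; beyond the scatter), a modest step beyond the scatter. One pair is thin support, so a step of similar size towards a lower number in this assay is expected, with wide uncertainty. The expected step is a 3.0-fold lower number from compound 3 to compound 4 (0.48 log units; beyond the scatter). Compound 4 is estimated at 290 nM, with an expected range of 130 nM to 650 nM.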

Compound 4, half-maximal inhibitory concentration: 1350 nM
For compound 4 the middle estimate is 4.7-fold (0.67 log units) below the measured one; the measured number lies above the stated range.
By their numbers in this assay, from the lowest: compound 2; then compounds 1, 3 and 4 (each within the scatter of the next).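

In this assay, but-1-en-1-yl in place of 1-chloroethenyl on the carbonyl carbon gives a 1.5-fold higher number from compound 3 to compound 4 (0.19 log units; within the scatter), so the gain seen on the core of compound 1 does not carry over to the core of compound 3. The outcome of this exchange at this position therefore differs with the core: the same change on two cores in this assay, a 3.0-fold lower number (0.48 log units; beyond the scatter) from compound 1 to compound 2 and a 1.5-fold higher number (0.19 log units; within the scatter) from compound 3 to compound 4, 4.6-fold (0.67 log units) apart, beyond the scatter of two such steps.

With one pair per core, these compounds do not show why the two cores part. As far as these compounds go, whether a plain ethenyl group or a longer chain such as pent-1-en-1-yl on the same carbonyl carbon would also differ between the two cores remains open.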